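Aminoglycoside-derived lipophilic ethers: cytotoxicity at one concentration

The compounds below may be only part of what the source reports. "The series", "measured", "known", "first", "only" and "open" are said of these compounds alone.

Measured compounds
compound 1 `C=CCO[C@H]1O[C@H](CN)[C@@H](OCCCCCCCCC)[C@H](OCCCCCCCCC)[C@H]1N` — compound 1 gives 91.4%
compound 2 `NC[C@H]1O[C@H](O[C@H]2[C@H](O)[C@@H](O)[C@H](N)C[C@@H]2N)[C@H](N)[C@@H](OCCCc2ccc3ccccc3c2)[C@@H]1OCCCc1ccc2ccccc2c1` — compound 2 gives 87.7%

Both numbers come from a toxicity assay on the whole organism (J774 cells) for cytotoxicity, with Mus musculus as the target, read by MTT assay, with a stated time of 24 h, tested at 10 uM; on this read-out higher numbers stand for a weaker effect at the one concentration tested and lower numbers for a stronger effect. Compound 2 has one neighbour only, compound 1, and the two values lie within the usual scatter of each other, so nothing separates compound 2 from compound 1 on this read-out: both keep most of the cell viability at the concentration used.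

Compound 3 `C=CCO[C@H]1O[C@H](CN)[C@@H](OCCCc2ccc3ccccc3c2)[C@H](OCCCc2ccc3ccccc3c2)[C@H]1N` is not yet measured in this assay. It differs from compound 2 in one place: allyl in place of 4,6-diamino-2,3-dihydroxycyclohexyl on an oxygen on a saturated carbon. Among the compounds with values here, the two naphthylpropyl chains of compound 2 are kept, and the allyl group is the one also carried by compound 1.

Within the data shown here, no step between measured compounds exists to calibrate this change. Compound 1, which carries the allyl group with different chains, gives 91.4%, and compound 2 gives 87.7%, both within the scatter of each other; the step from compound 2 to compound 3 is therefore expected to be none beyond the scatter, a number 1.3 percentage points higher from compound 2 to compound 3 (within the scatter). For compound 3 in this assay the value is estimated at 89%, with a range of 79% to 97%.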

Compound 3, a percentage reported as activity, at one concentration (the size of the read-out at that concentration, not a potency): 105%
Estimate against measurement, compound 3: 16 percentage points below, and the stated range ends below it.
By their numbers in this assay, from the lowest: compounds 2 and 1 (each within the scatter of the next); then compound 3.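

In this assay, putting allyl in place of 4,6-diamino-2,3-dihydroxycyclohexyl on an oxygen on a saturated carbon gives a number 17.3 percentage points higher from compound 2 to compound 3 (beyond the scatter), which on this read-out is a move towards a weaker effect at the one concentration tested. Within the data shown here, the earlier compounds gave no step at all, so this is the first sign that the group on this oxygen can move the read-out beyond the scatter, here with the two naphthylpropyl chains held constant. Nothing measured here accounts for the step.

Among these compounds, the series rests on this single pair at a single concentration, so it stays open whether the step would keep its size with the nonyl chains of compound 1 in place of the naphthylpropyl chains, and it gives no potency for either compound. Also open, as far as these compounds go, is how the read-out would respond on this oxygen to a group between the two extremes, such as a simple aminoethyl chain, or to a longer chain in place of the naphthylpropyl ethers.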